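This account rests on a few compounds, and the source may have more. Where it says the series, first, only, none or still open, it means among the compounds named here.

Compound 1 is `COc1ccc(-n2c(SC)nnc2-c2cc(OC)c(OC)c(OC)c2)cc1`; in a functional assay on HT-29 cells (Homo sapiens) for inhibition, read by MTT assay, with a stated time of 48 h (a lower number here means a stronger inhibitor, a higher number a weaker inhibitor), compound 1 gives > 60000 nM, which is a limit of the assay rather than a number.
Compound 2 is `COc1ccc(-n2c(SCc3ccccc3)nnc2-c2cc(OC)c(OC)c(OC)c2)cc1`; in this assay compound 2 gives > 60000 nM, again a limit.

Going by the values given here, compound 1 thus has no measured number in this assay, only a limit, and the one other value shown is a limit as well. Among the compounds with values here, the single step between measured compounds, a step that the two limits leave unreadable from compound 1 to compound 2, phenyl in place of hydrogen on a saturated chain carbon bound to a sulfur, cannot be read: both ends sit at the same limit, (the limit of > 60000 nM in this assay, at which 2 of the 2 values shown sit). Compound 3 is `CCOC(=O)CSc1nnc(-c2cc(OC)c(OC)c(OC)c2)n1-c1ccc(OC)cc1`. It differs from compound 1 by ethoxycarbonyl in place of hydrogen on a saturated chain carbon bound to a sulfur; cut one bond further out the change reads methyl to (ethoxycarbonyl)methyl, or methylsulfanyl to ((ethoxycarbonyl)methyl)sulfanyl. Within the data shown here, the only measured step at this same place gave no readable size, so the data give no basis for expecting a step in this assay in either direction beyond the scatter, and compound 3 is expected to sit at the limit too. The expected step is a step that the limit leaves unreadable from compound 1 to compound 3. For compound 3 the estimate is 80000 nM, with a range from 30000 nM to 300000 nM.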

Compound 3, half-maximal inhibitory concentration: > 60000 nM
Compound 3: no number, only a limit; the forecaster's own chance of this, stated with the estimate: 85%; the middle value lies beyond the limit too.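

Going by these compounds alone, no step among compound 1, compound 2 and compound 3 can be read in this assay, because all three sit at one limit rather than at a number: the limit of > 60000 nM in this assay, at which 3 of the 3 values shown sit. The compounds shown leave open whether any group on the saturated chain carbon bound to a sulfur would give a readable value.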